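This account rests on a few compounds, and the source may have more. Where it says the series, first, only, none or still open, it means among the compounds named here.

Among the measured compounds shown here, compound 2 `CCOC(=O)C(=O)CC(=O)/C=C/c1cn(Cc2ccc(Cl)cc2)c2ccccc12` in an assay on isolated protein for inhibition of DNA nucleotidylexotransferase (Homo sapiens), read by scintillation counting, with a stated time of 10 min (a higher number here means a weaker inhibitor, a lower number a stronger inhibitor), gives 40 uM, the only plain number in the set. Compound 1 `C/C=C/Cn1cc(/C=C/C(=O)CC(=O)C(=O)OCC)c2ccccc21` gives a limit in this assay, > 40 uM. The step of a number no higher from compound 1 to compound 2 (the limit leaves the size open) therefore has no readable size, resting on (the limit of > 40 uM in this assay, at which 1 of the 2 values shown sits). Compound 3 `O=C(/C=C/c1cn(Cc2ccc(Cl)cc2)c2ccccc12)CC(=O)C(=O)O` differs from compound 2 at the ester: hydrogen in place of ethyl on an oxygen next to a carbonyl group. For the measured compounds named here, no measured step touches that position, so nothing in the set fixes a direction or a size, and the expected step of a 1.6-fold lower number from compound 2 to compound 3 (0.20 log units; within the scatter) is taken as roughly level with wide uncertainty. Compound 3 is estimated at 25 uM in this assay, with a range from 6 uM to 80 uM.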

Compound 3, concentration for 50% inhibition: 10 uM
Estimate against measurement, compound 3: 2.5-fold (0.40 log units) above; the range from low to high includes it.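

In this assay, among the compounds shown here, the ester position gives the first step of readable size, since the one earlier step cannot be read: hydrogen in place of ethyl on an oxygen next to a carbonyl group, ethoxycarbonyl to carboxy, gives a 4.0-fold lower number from compound 2 to compound 3 (0.60 log units; beyond the scatter). This position therefore responds to the change, and the carboxy form is the stronger of this pair. Nothing shown gives a cause for this step.

From the compounds shown here alone, a methyl ester, a longer chain ester or a primary amide at this position remains open. Also open, going by these compounds, is whether the same change carries over with the prop-1-en-1-yl chain of compound 1.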